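Swapping Phenyl for Pyrimidinyl in a Glycine Transporter Amide Series

This account rests on a few compounds, and the source may have more. Where it says the series, first, only, none or still open, it means among the compounds named here.

Of the compounds shown here, three have been measured in an assay on cells for inhibition of sodium- and chloride-dependent glycine transporter 1 (Homo sapiens); on this read-out lower numbers stand for an effect already at smaller amounts and higher numbers for an effect only at larger amounts of compound. Compound 1 `COc1cc(C(F)(F)F)ccc1C(=O)NC1(c2ccccc2)CCCN(C)C1` gives 4800 nM. Compound 2 `COc1cc(C(F)(F)F)cc(SC)c1C(=O)NC1(c2ccccc2)CCCN(C)C1` gives 24 nM, and compound 3 `COc1cc(C(F)(F)F)cc(SC)c1C(=O)N[C@@]1(c2ccccc2)CCCN(C)C1` gives 10 nM. Among these numbers compound 2 stands second highest of the three, with compound 3 nearest and compound 1 furthest. The step of a 200-fold lower number from compound 1 to compound 2 (2.30 log units; beyond the scatter) goes with methylsulfanyl in place of hydrogen on an aromatic carbon. The step of a 2.4-fold lower number from compound 2 to compound 3 (0.38 log units; beyond the scatter) goes with the fact that one of compounds 2 and 3 is drawn with a defined configuration and the other without, at the place where they differ.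

Compound 4 `COc1cc(C(F)(F)F)cc(SC)c1C(=O)NC1(c2ncccn2)CCCN(C)C1` differs from compound 2 in one place: pyrimidin-2-yl in place of phenyl on a saturated ring carbon. Neither measured step alters the group on the saturated ring carbon, so neither bears directly on this change, and the measured values give no guide to its size. For the measured compounds named here, with no comparable step to lean on, only a modest shift toward a higher number in this assay is expected. The step of a 2.1-fold higher number from compound 2 to compound 4 (0.32 log units; beyond the scatter) is the estimated outcome. For compound 4 the estimate in this assay is 50 nM, expected to lie between 12 nM and 200 nM.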

Compound 4, half-maximal effective concentration: > 10000 nM
Compound 4 gave a limit, no number; the forecaster's own chance of this, stated with the estimate: 3%; at least 200-fold (2.30 log units) between middle value and limit.
By their numbers in this assay, from the lowest: compound 3; then compound 2; then compound 1. At a limit, above all of these: compound 4.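

In this assay, the change from phenyl to pyrimidin-2-yl on the saturated ring carbon goes with an at least 410-fold higher number from compound 2 to compound 4 (2.61 log units; beyond the scatter). Compound 4 carries a limit and not a number, so this step has a lower bound but no exact size: the limit of > 10000 nM in this assay, at which 1 of the 4 values shown sits. For the compounds shown here, all the earlier compounds keep phenyl at this place, and this pair shows that replacing that ring with another six-membered aromatic ring of the same heavy-atom count, now holding two nitrogens and two hydrogen-bond acceptors, can make a very large difference.

The compounds shown do not tell which of the two ring nitrogens goes with this loss. From the compounds shown here alone, it also stays open whether pyridin-2-yl, with a single ring nitrogen, or a phenyl ring carrying a fluorine would stay close to compound 2 at 24 nM.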